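This account rests on a few compounds, and the source may have more. Where it says the series, first, only, none or still open, it means among the compounds named here.

Three compounds share one core, and in a functional assay on MIA cells (Homo sapiens) for inhibition, read by MTT assay, with a stated time of 72 h (a lower number here means a stronger inhibitor of growth, a higher number a weaker inhibitor of growth), they give numbers spread over a modest range. Compound 1 `COc1ccc(CNC(=O)/C(C#N)=C/c2ccc(C)o2)cc1` gives 51000 nM. Compound 2 `COc1ccc(CNC(=O)/C(C#N)=C/c2ccc(Cl)cc2)cc1` gives 16000 nM. The change between them is a 3.2-fold lower number from compound 1 to compound 2 (0.50 log units; beyond the scatter). Compound 3 `COc1ccc(CNC(=O)/C(C#N)=C/c2ccc3ccccc3c2)cc1` gives 49000 nM, the second highest of the three numbers; its value and that of compound 1 lie within the scatter of each other, while compound 2 gives a lower number that lies beyond it.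

Compound 4 `N#C/C(=C\c1ccc2ccccc2c1)C(=O)NCc1ccc(Cl)c(Cl)c1` differs from compound 3 in a single place: 3,4-dichlorophenyl in place of 4-methoxyphenyl on a saturated chain carbon bound to an amide-type nitrogen. Within the data shown here, none of the measured steps touches this part of the molecule; the only step measured, from compound 1 to compound 2, changes the group at the other end of the double-bonded chain, so it speaks to this change only loosely. No clear direction can be drawn from the data for the step from compound 3 to compound 4, and a step within or just beyond the scatter is the plain expectation, estimated as a 1.6-fold lower number from compound 3 to compound 4 (0.21 log units; within the scatter). Compound 4 is therefore expected to give about 30000 nM, within a range from 10000 nM to 90000 nM.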

Compound 4, concentration for 50% growth inhibition: 44000 nM
Beside the measured number, compound 4's estimate is 1.5-fold (0.17 log units) below it; low and high end bracket the measured number.
By their numbers in this assay, from the lowest: compound 2; then compounds 4, 3 and 1 (each within the scatter of the next).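

In this assay, among these compounds, exchanging the one group that differs gives a 1.1-fold lower number from compound 3 to compound 4 (0.05 log units; within the scatter), so this exchange leaves the number effectively unmoved on the core of compound 3. Among the compounds shown here, this is the first reading at this position, and it differs from the only earlier step, a 3.2-fold lower number from compound 1 to compound 2 (0.50 log units; beyond the scatter), which changes a different place on the molecule and lies beyond the scatter. Nothing measured here explains the result.

Going by these compounds, it remains open whether a group of another kind at this position, such as an amine or a carboxylic acid in place of the substituted phenyl ring, would shift the number. On these data alone, it is also open whether the same exchange would leave the number unmoved on the core of compound 2.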